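This account rests on a few compounds, and the source may have more. Where it says the series, first, only, none or still open, it means among the compounds named here.

Compound 3 `Fc1ccc(Cc2ccc3c(NCCCNCc4ccco4)ccnc3c2)cc1` carries a 4-fluorobenzyl group on the shared core. In an ADME assay for permeability, using PAMPA, with a stated time of 30 min, at pH 7.4 (on this read-out higher numbers stand for higher permeability and lower numbers for lower permeability), compound 3 gives 23 10^-6 cm/s, level with compound 1 `Fc1ccc(Cc2ccc3c(NCCCNCc4ccco4)ccnc3c2)c(Cl)c1`, which gives 23 10^-6 cm/s, and the two stand together as the lowest of the three numbers; the step of no change at the digits printed from compound 1 to compound 3 (within the scatter) lies within the scatter. Compound 2 `FC(F)(F)c1ccc(-c2ccc3c(NCCCNCc4ccco4)ccnc3c2)cc1` stands apart, giving 237 10^-6 cm/s, and the step of a 10-fold lower number from compound 2 to compound 3 (1.01 log units; beyond the scatter) is large, as is a 10-fold higher number from compound 1 to compound 2 (1.01 log units; beyond the scatter).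

Compound 4 `N#Cc1ccc(Cc2ccc3c(NCCCNCc4ccco4)ccnc3c2)cc1` differs from compound 3 in one place: cyano in place of fluoro on an aromatic carbon. Among the compounds with values here, no measured step swaps these two groups. Within the data shown here, the only step confined to the same benzyl ring, no change at the digits printed from compound 1 to compound 3 (within the scatter), brought no change beyond the scatter, while the large steps of a 10-fold higher number from compound 1 to compound 2 (1.01 log units; beyond the scatter) and a 10-fold lower number from compound 2 to compound 3 (1.01 log units; beyond the scatter) exchange the whole 4-(trifluoromethyl)phenyl for a benzyl and so have little to say about a cyano for fluoro swap. The step of a 1.5-fold lower number from compound 3 to compound 4 (0.19 log units; within the scatter) is therefore expected to be modest, probably within the scatter, leaning downward. Compound 4 is estimated at 15 10^-6 cm/s, within a range from 6 10^-6 cm/s to 40 10^-6 cm/s.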

Compound 4, apparent permeability: 23 10^-6 cm/s
For compound 4 the middle estimate is 1.5-fold (0.19 log units) below the measured one; the measured number falls inside the stated range.
By their numbers in this assay, from the lowest: compounds 1, 3 and 4 (each within the scatter of the next); then compound 2.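

In this assay, within the data shown here, the first direct swap at this position, para to a large group, gives no change at the digits printed from compound 3 to compound 4 (within the scatter), even though cyano brings one more heavy atom than fluoro and a hydrogen-bond acceptor that fluoro lacks. The wider exchange of 2-chloro-4-fluorophenyl for 4-cyanophenyl on the same saturated chain carbon gives no change at the digits printed from compound 1 to compound 4 (within the scatter), so compounds 1, 3 and 4 stand level across all three benzyl ring patterns shown. The large gap to the 4-(trifluoromethyl)phenyl compound also holds for the new group, with a 10-fold lower number from compound 2 to compound 4 (1.01 log units; beyond the scatter), so among these four compounds the only large steps are those that exchange that group for a substituted benzyl, and compound 2 is the one that stands apart.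

Nothing in the data at hand accounts for these level numbers or for the gap to compound 2. From the compounds shown here alone, it remains open whether an amine or a carboxylic acid at this position would also leave the number level, and whether cyano would give the same result on a phenyl joined directly to the shared core.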